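A few compounds are considered here, and "the series" means these few. Any claim that something is new, unique, unknown or untested is made for them only; others in the source may bear on it.

Measured so far in an assay on membranes from lung (Cavia porcellus) for binding affinity to cysteinyl leukotriene receptor (Homo sapiens); on this read-out lower numbers stand for stronger inhibition and higher numbers for weaker inhibition:

compound 1 `CC(CCCC(=O)O)c1cccc(OCc2ccc3ccccc3n2)c1` — 90 nM
compound 2 `c1ccc2nc(COc3ccc(OCCCc4nnn[nH]4)cc3)ccc2c1` — 69 nM

Compound 2 holds the lower of the two numbers in this assay, but the gap to compound 1, which gives 90 nM, is within the scatter, so the two values show no order between them. For the measured compounds named here, no step between measured compounds that differ in a single place is available, so nothing so far tells how much any one change is worth.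

Compound 3 `O=C(O)C1CCC(c2ccc(OCc3ccc4ccccc4n3)cc2)C1` is not yet measured. It differs from compound 2 in one place: 3-carboxycyclopentyl in place of 3-(1H-tetrazol-5-yl)propoxy on an aromatic carbon. A carboxylic acid on a side chain is already present in compound 1, which gives 90 nM in this assay, and that number sits within the scatter of compound 2. On that basis the step from compound 2 to compound 3 is expected to be small, at most slightly toward a higher number, and may not exceed the scatter. Compound 3 is expected to give 120 nM in this assay, with a range from 30 nM to 500 nM. The expected step is a 1.7-fold higher number from compound 2 to compound 3 (0.24 log units; within the scatter).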

Compound 3, inhibition constant: 43 nM
Estimate against measurement, compound 3: 2.8-fold (0.45 log units) above; the range from low to high includes it.
By their numbers in this assay, from the lowest: compounds 3, 2 and 1 (each within the scatter of the next, the first and the last beyond it).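

In this assay, the aromatic carbon para to a large group takes 3-carboxycyclopentyl in place of 3-(1H-tetrazol-5-yl)propoxy and the read-out shows a 1.6-fold lower number from compound 2 to compound 3 (0.21 log units; within the scatter), which gives the series its first step at a single place. That step replaces a five-membered aromatic ring with 4 hetero atoms by a five-membered non-aromatic ring of carbon only, and 4 hydrogen-bond acceptors by 1, while the count of 1 hydrogen-bond donor stays the same, so at this position the read-out does not separate two groups that differ this much in their make-up. Nothing measured here accounts for the two groups reading alike.

On these data alone, the step exchanges the ring and the chain together, so the share of each stays open: a carboxylic acid on a propoxy chain would separate the acid from the carbocyclic ring, and a tetrazole carried on a cyclopentyl ring would test the reverse exchange. Also open, as far as these compounds go, is whether a group without an acid at this position, such as a primary amine or a plain longer alkyl chain, reads the same in this assay.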